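Cytotoxicity Readings Towards a Fourth Fluorinated Analogue

A few compounds are considered here, and "the series" means these few. Any claim that something is new, unique, unknown or untested is made for them only; others in the source may bear on it.

Measured compounds:
compound 1 `O=c1[nH]c(Nc2ccc(F)c(F)c2F)nc2cc(Cl)ccc12`: > 25000 nM
compound 2 `O=c1[nH]c(Nc2ccccc2F)nc2cc(Cl)ccc12`: > 25000 nM
compound 3 `O=c1[nH]c(Nc2ccc(F)cc2)nc2cc(Cl)ccc12`: > 25000 nM

In an ADME assay on Vero cells (Chlorocebus sabaeus) for cytotoxicity, read by WST assay (on this read-out lower numbers stand for higher toxicity in this test and higher numbers for lower toxicity in this test), compound 3 gives only a limit, > 25000 nM, and no number. The same holds for the other two: compound 1 in this assay stops at > 25000 nM. Compound 2 likewise stops at > 25000 nM in this assay. So all three measured members of the series share one reading, which is the limit of > 25000 nM in this assay, at which 3 of the 3 values shown sit; no member has yet shown a measurable half-maximal cytotoxic concentration, and no ranking among them is possible.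

Compound 4 `O=c1[nH]c(Nc2ccc(F)cc2F)nc2cc(Cl)ccc12` is the next member to be run in this assay. It differs from compound 3 by fluoro in place of hydrogen on an aromatic carbon, in words fluoro in place of hydrogen on an aromatic carbon. Within the data shown here, there is no measured pair that isolates this change, so no step can be quoted for it. Given that compound 3 and its two neighbours all sit at the limit, the expectation for compound 4 is no step beyond the scatter, in either direction, in this assay; the expected step is a step that the limit leaves unreadable from compound 3 to compound 4. Compound 4 is thus estimated at 40000 nM, within 20000 nM to 100000 nM, most likely again reported as a limit rather than a number.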

Compound 4, half-maximal cytotoxic concentration: > 25000 nM
Compound 4 gave a limit, no number; the forecaster's own chance of this, stated with the estimate: 85%; the middle value does not contradict the limit.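

No step can be read from compound 4 to compound 1, compound 2 or compound 3, since each of these pairs offers only limits and no numbers: the limit of > 25000 nM in this assay, at which 4 of the 4 values shown sit.

The compounds shown leave open where the half-maximal cytotoxic concentration of any of the four actually lies, and whether the fluoro groups alter it at all.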